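This account rests on a few compounds, and the source may have more. Where it says the series, first, only, none or still open, it means among the compounds named here.

Three compounds share one core and differ only in a single group on an aromatic carbon. Compound 1 `CC#C[C@H](CC(=O)O)c1ccc(OC[C@H]2COc3ccc(Cl)cc3O2)cc1`, compound 2 `CC#C[C@@H](CC(=O)O)c1ccc(OC[C@H]2COc3ccc(F)cc3O2)cc1` and compound 3 `CC#C[C@@H](CC(=O)O)c1ccc(OC[C@H]2COc3ccc(C)cc3O2)cc1` have all been measured in a functional assay on HEK293 cells for agonist activity at Free fatty acid receptor 1 (Homo sapiens), read by fluorescence and calcium flux, with a stated time of 10 min; a higher number here means a larger maximal response, a lower number a smaller maximal response. Compound 1 gives 47%, compound 2 gives 86% and compound 3 gives 78%. Among these three numbers compound 3 stands second highest, close to compound 2 and well above compound 1. Going by the values given here, the single change between neighbours that was measured, a number 8 percentage points lower from compound 2 to compound 3 (within the scatter), lies within the scatter.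

Compound 4 `CC#C[C@@H](CC(=O)O)c1ccc(OC[C@H]2COc3ccc(CO)cc3O2)cc1` has not yet been measured. Relative to compound 3 it carries hydroxy in place of hydrogen on a saturated chain carbon bound to an aromatic carbon. Among the compounds with values here, no measured step touches this kind of change; the only change measured on an aromatic carbon, methyl in place of fluoro, left the largest response essentially where it was. On that basis, and since the change is a small one, the number for compound 4 in this assay is expected close to that of compound 3, with an expected step of a number 3 percentage points lower from compound 3 to compound 4 (within the scatter). The estimate for compound 4 is 75%, with a range from 55% to 92%.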

Compound 4, largest response reached (Emax), in percent of the reference or control that the assay uses: 42%
Compound 4: middle estimate off by 33 percentage points, on the high side; the measured number lies below the stated range.
By their numbers in this assay, from the lowest: compounds 4 and 1 (each within the scatter of the next); then compounds 3 and 2 (each within the scatter of the next).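

Going by these compounds alone, this position is less forgiving than the earlier compounds suggested. Swapping one small group for another there had looked harmless, with a number 8 percentage points lower from compound 2 to compound 3 (within the scatter), but in this assay a single added hydroxy on the saturated chain carbon bound to an aromatic carbon, turning methyl into hydroxymethyl, gives a number 36 percentage points lower from compound 3 to compound 4 (beyond the scatter), and the comparison with the fluoro compound gives a number 44 percentage points lower from compound 2 to compound 4 (beyond the scatter). So the largest response at this receptor does depend on the group here, and a change of only one heavy atom is enough to lower it well beyond the usual scatter. Nothing available explains why this one oxygen atom has such an effect on the response.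

The compounds shown leave open whether the loss belongs to the free hydroxy itself or would also appear with other groups on this chain carbon, such as a methoxymethyl, an aminomethyl or a carboxylic acid. They also leave open whether a longer chain such as hydroxyethyl, which would carry the hydroxy further out, would bring the response back towards that of compound 3.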